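This account rests on a few compounds, and the source may have more. Where it says the series, first, only, none or still open, it means among the compounds named here.

Working notes on the series. For the measured compounds named here, compound 1 `Fc1ccc(/C=N/Nc2nc(-c3ccc(C(F)(F)F)cc3)cs2)cc1F` gives, in a functional assay on HepG2 cells (Homo sapiens) for inhibition, read by MTT assay, with a stated time of 48 h (on this read-out higher numbers stand for weaker inhibition and lower numbers for stronger inhibition), a value of 14500 nM, the lower of the two numbers so far. Compound 2 `COc1cc(/C=N/Nc2nc(-c3ccc(Br)cc3)cs2)cc(Br)c1OC` gives 64600 nM in this assay, a higher number with a gap beyond the scatter. Compound 3 `Fc1ccc(/C=N/Nc2nc(-c3ccccc3)cs2)cc1F` has not yet been measured. It differs from compound 1 by hydrogen in place of trifluoromethyl on an aromatic carbon. Going by the values given here, no step between measured compounds covers this change, so the size of the step is uncertain; in this assay a modest move toward a higher number is expected, possibly still within the scatter, as a 1.7-fold higher number from compound 1 to compound 3 (0.24 log units; within the scatter). On that basis compound 3 is estimated at 25000 nM, within 8000 nM to 80000 nM.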

Compound 3, half-maximal inhibitory concentration: > 100000 nM
Compound 3: only a limit was reported; the forecaster's own chance of this, stated with the estimate: 15%; at least 4.0-fold (0.60 log units) between middle value and limit.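

For the compounds shown here, on an aromatic carbon para to a large group, trifluoromethyl gives way to hydrogen in the first one-place change that can be read: an at least 6.8-fold higher number from compound 1 to compound 3 (0.83 log units; beyond the scatter). In this assay compound 3 gives > 100000 nM, which is a limit of the assay and not a number. The step therefore sets only a lower bound on the change, because compound 3 rests on that limit: the limit of > 100000 nM in this assay, at which 1 of the 3 values shown sits.

Only trifluoromethyl and hydrogen are compared at this place on the shared core. From the compounds shown here alone, whether an amine or a carboxylic acid there would give a number nearer to that of compound 1 remains open.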